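Half-life in buffer across the bis-trifluoromethylphenyl series

The compounds below may be only part of what the source reports. "The series", "measured", "known", "first", "only" and "open" are said of these compounds alone.

Measured so far in an ADME assay for pharmacokinetics, read by HPLC, in phosphate buffer, with a stated time of 72 h, at pH 7.4, tested at 250 uM; on this read-out lower numbers stand for a shorter-lived compound and higher numbers for a longer-lived compound:
- compound 1, `O=C1C=CC(=O)N1c1cc(C(F)(F)F)cc(C(F)(F)F)c1`: < 0.017 h
- compound 2, `O=C(CBr)c1cc(C(F)(F)F)cc(C(F)(F)F)c1`: < 0.017 h
- compound 3, `FC(F)(F)c1cc(C2CO2)cc(C(F)(F)F)c1`: 6 h

Compound 1 carries the shared core with a five-membered ring of four carbon, one nitrogen and two oxygen atoms on an aromatic carbon. In this assay compound 1 gives only a limit, < 0.017 h, and not a number. Compound 2 likewise sits at a limit, < 0.017 h. Both share (the limit of < 0.017 h in this assay, at which 2 of the 3 values shown sit), so the step that the two limits leave unreadable from compound 1 to compound 2 cannot be read. Compound 3 returns a number, 6 h, and the step of an at least 350-fold higher number from compound 1 to compound 3 (2.54 log units; beyond the scatter) is large; so is an at least 350-fold higher number from compound 2 to compound 3 (2.54 log units; beyond the scatter).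

Compound 4, `Fc1cc(C(F)(F)F)cc(C(F)(F)F)c1`, has not yet been measured. The change from compound 1 is one fluorine atom in place of a group of 7 heavy atoms (4 carbon, 1 nitrogen, 2 oxygen; one five-membered non-aromatic ring with 1 hetero atom), on an aromatic carbon. Among the compounds with values here, of the measured steps, only the one from compound 1 to compound 3 gives a readable size, and it shows that exchanging the five-membered ring for a smaller group raises the half-life by a large margin; the step to compound 2 sets no bound either way. For compound 4 the expectation is therefore a large upward step, an at least 11000-fold higher number from compound 1 to compound 4 (4.07 log units; beyond the scatter), most likely running into the upper limit of the measurement window. The estimated half-life of compound 4 is 200 h, with a range from 48 h to 2000 h.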

Compound 4, half-life: 11 h
Compound 4: the middle estimate sits 18-fold (1.26 log units) above what was measured, outside the stated range (below it).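

Within the data shown here, on this aromatic carbon, meta to two trifluoromethyl groups, the single fluoro group gives a reading far from the short-lived end of this assay, with an at least 640-fold higher number from compound 1 to compound 4 (2.81 log units; beyond the scatter) and an at least 640-fold higher number from compound 2 to compound 4 (2.81 log units; beyond the scatter), both sizes resting on a limit for the first compound of the pair. Fluoro and oxiran-2-yl are not told apart on this read-out, with a 1.8-fold higher number from compound 3 to compound 4 (0.26 log units; within the scatter), so a half-life in this range is not peculiar to the oxiran-2-yl group and is also seen with a group of one heavy atom and no ring. The short-lived end of the series still rests on compound 1 and compound 2 alone, whose readings are limits and cannot be ordered against each other: the limit of < 0.017 h in this assay, at which 2 of the 4 values shown sit.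

Going by these compounds, whether an amine, a carboxylic acid or a nitrile on this same carbon would read with compound 3 and compound 4 or with compound 1 and compound 2 remains open. Also open, on these data alone, is what part the two trifluoromethyl groups play in these readings, as they stand unchanged in all four compounds.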